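The source may hold more compounds than are shown below. What is called first, only, known or untested is meant among the compounds shown, and "the series" means these compounds.

Compound 1 `O=C(CCCCC[C@H](NC(=O)OCc1ccccc1)C(=O)NCc1ccccc1)NO`: 1520 nM
Compound 2 `O=C(CCCCC[C@H](NC(=O)c1ccc(C(F)(F)F)cc1)C(=O)NCc1ccccc1)NO`: 1610 nM

In a functional assay on NFF cells (Homo sapiens) for antiproliferative activity (on this read-out higher numbers stand for weaker inhibition and lower numbers for stronger inhibition), compound 2 gives 1610 nM, the higher of the two numbers shown, although the step of a 1.1-fold higher number from compound 1 to compound 2 (0.02 log units; within the scatter) is within the scatter. Compound 3 `CN(C)c1ccc(NC(=O)[C@H](CCCCCC(=O)NO)NC(=O)c2ccc(C(F)(F)F)cc2)cc1` differs from compound 2 by 4-(dimethylamino)phenyl in place of benzyl on an amide-type nitrogen. Among the measured compounds shown here, no measured step touches the amide-type nitrogen; the only step available, a 1.1-fold higher number from compound 1 to compound 2 (0.02 log units; within the scatter), concerns the carbonyl carbon and was within the scatter. There is therefore no basis for expecting a change beyond the scatter, and the expected step of a 1.1-fold lower number from compound 2 to compound 3 (0.03 log units; within the scatter) is small. Compound 3 is estimated at 1500 nM, with a range from 500 nM to 5000 nM.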

Compound 3, half-maximal inhibitory concentration: 400 nM
Compound 3: the middle estimate sits 3.8-fold (0.57 log units) above what was measured; measured number below the stated range.
By their numbers in this assay, from the lowest: compound 3; then compounds 1 and 2 (each within the scatter of the next).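

In this assay, the change on the amide-type nitrogen gives a 4.0-fold lower number from compound 2 to compound 3 (0.60 log units; beyond the scatter), so this position, unlike the carbonyl carbon varied earlier, shifts the number beyond the scatter. The new group brings one nitrogen and one hydrogen-bond acceptor by count, but no measurement available here accounts for the step.

The compounds shown leave open whether the step belongs to the dimethylamino group or to the exchange of benzyl for a phenyl group, which plain phenyl on the same nitrogen would separate. They also leave open whether the step holds with benzyloxy on the carbonyl carbon.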